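Triazole sulfonamides on ovarian cancer cells: one expected value

A few compounds are considered here, and "the series" means these few. Any claim that something is new, unique, unknown or untested is made for them only; others in the source may bear on it.

Measured compounds:
Compound 1 `Cc1ccc(-n2cc(-c3cccc(NS(=O)(=O)c4c[nH]c(=O)[nH]c4=O)c3)nn2)cc1` gives 3540 nM in a functional assay on OVCAR-3 cells (Homo sapiens) for antiproliferative activity, read by MTT assay, with a stated time of 24 h; a higher number here means a weaker inhibitor, a lower number a stronger inhibitor.
Compound 2 `O=c1[nH]cc(S(=O)(=O)Nc2cccc(-c3cn(-c4ccccc4F)nn3)c2)c(=O)[nH]1` gives 12500 nM.
Compound 3 `Cc1ccc(-n2cc(-c3ccc(NS(=O)(=O)c4c[nH]c(=O)[nH]c4=O)cc3)nn2)cc1` gives 5630 nM.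

Compound 1 and compound 3 are built from the same atoms joined differently; the difference between the two cores is not broken down here. Compound 2 differs from compound 1 by 2-fluorophenyl in place of 4-methylphenyl on an aromatic nitrogen, and this change produced a 3.5-fold higher number from compound 1 to compound 2 (0.55 log units; beyond the scatter).

Compound 4 `O=c1[nH]cc(S(=O)(=O)Nc2ccc(-c3cn(-c4ccccc4F)nn3)cc2)c(=O)[nH]1` has not been measured. It differs from compound 3 by 2-fluorophenyl in place of 4-methylphenyl on an aromatic nitrogen, the same change at the same place as between compound 1 and compound 2. A comparable step is therefore expected, namely a 3.0-fold higher number from compound 3 to compound 4 (0.48 log units; beyond the scatter), because a 3.5-fold higher number from compound 1 to compound 2 (0.55 log units; beyond the scatter) was seen once already. Compound 4 is accordingly estimated at 17000 nM, with an expected range from 7000 nM to 40000 nM.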

Compound 4, half-maximal inhibitory concentration: 8030 nM
For compound 4 the middle estimate is 2.1-fold (0.33 log units) above the measured one, and the stated range covers the measured number.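

Placing 2-fluorophenyl where 4-methylphenyl stood gives, in this assay, a 1.4-fold higher number from compound 3 to compound 4 (0.15 log units; within the scatter), so on this core the change cannot be told apart from ordinary repeat variation. Set beside the earlier step, the two results do not clearly differ: the same change on two cores in this assay, a 3.5-fold higher number (0.55 log units; beyond the scatter) from compound 1 to compound 2 and a 1.4-fold higher number (0.15 log units; within the scatter) from compound 3 to compound 4, 2.5-fold (0.39 log units) apart, within the scatter of two such steps. As far as these data can tell, the change carries across the two cores, but a single pair on each core cannot show that its effect is truly the same size, and it says nothing about why the numbers move.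

Only 4-methylphenyl and 2-fluorophenyl appear on the aromatic nitrogen here. Going by these compounds, it remains open how a benzyl group, a longer alkyl chain or an amine-bearing group would behave there on either core.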